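The source may report more compounds than this note shows. Statements on the series, on what has been measured and on what is new or still open speak of the compounds shown alone.

In a functional assay on HepG2 cells (Homo sapiens) for cytotoxicity, read by MTT assay, with a stated time of 48 h (on this read-out higher numbers stand for weaker inhibition and lower numbers for stronger inhibition), compound 1 (`COc1cc(C2Oc3c(OC)cc(/C=C/C=O)cc3C2CO)ccc1O`) gives 36500 nM and compound 2 (`COc1cc([C@H]2Oc3c(OC)cc(/C=C/C=O)cc3[C@@H]2CO)ccc1O`) gives 38100 nM as its own value. Going by the values given here, these are the only two numbers so far, and they sit within the scatter of each other, so compound 2 stands level with compound 1. What separates the pair is the fact that one of compounds 1 and 2 is drawn with a defined configuration and the other without, at the place where they differ and nothing else in the structure.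

Compound 3 (`COc1cc([C@H]2Oc3c(OC)cc(/C=C/C=O)cc3[C@@H]2CO)cc(OC)c1O`) comes from compound 2 by one change: methoxy in place of hydrogen on an aromatic carbon, ortho to a hydroxy group (methoxy in place of hydrogen on an aromatic carbon). Among the compounds with values here, no measured step involves such a change. The only one available, a 1.0-fold higher number from compound 1 to compound 2 (0.02 log units; within the scatter) in size, concerns drawn configuration and gives no direction for a new methoxy, so the expectation rests on little more than the level of compound 2 at 38100 nM in this assay.

The expected move is a 1.0-fold higher number from compound 2 to compound 3 (0.02 log units; within the scatter) and thus none beyond the scatter. With so little evidence the range has to be wide. For compound 3 the estimate is 40000 nM (expected range 15000 nM to 100000 nM).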

Compound 3, half-maximal inhibitory concentration: 88700 nM
Estimate against measurement, compound 3: 2.2-fold (0.35 log units) below; low and high end bracket the measured number.
By their numbers in this assay, from the lowest: compounds 1 and 2 (each within the scatter of the next); then compound 3.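

In this assay, this position on the six-membered aromatic ring of carbon only proves sensitive to substitution: a methoxy group in place of hydrogen, ortho to a hydroxy group, gives a 2.3-fold higher number from compound 2 to compound 3 (0.37 log units; beyond the scatter). This is the first step shown to lie beyond the scatter, and although it is modest, its direction is towards weaker inhibition, whereas the earlier step, which concerned only drawn configuration, gave no such difference. The available information on drawn configuration does not bear on this methoxy change, so nothing here accounts for the shift.

From the compounds shown here alone, a single new group at a single place gives no trend, so it remains open whether a fluorine atom, a methyl group or a longer chain such as ethoxy on the same carbon would move the number in the same direction or by a similar amount. Going by these compounds, it is equally open whether the methoxy group would give a similar step if the hydroxy group to which it stands ortho were exchanged for an amine.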